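The compounds below may be only part of what the source reports. "The series", "measured", "known", "first", "only" and "open" are said of these compounds alone.

Of the compounds shown here, three of one family have been tested in a functional assay on PC-12 cells (Rattus norvegicus) for cytotoxicity, read by MTT assay, with stated times of 3 h and 2 h, tested at 5 uM; on this read-out higher numbers stand for a stronger effect at the one concentration tested and lower numbers for a weaker effect. Compound 1 `COc1ccc(-c2cc3ccc(OCCCn4cc(CNC(=O)CCCCC5CCSS5)nn4)cc3oc2=O)cc1` gives 52.8% in this assay. Compound 2 `Cc1cc(=O)oc2cc(OCCCCCn3cc(CNC(=O)CCCCC4CCSS4)nn3)ccc12` gives 61%. Compound 3 `CC(=O)c1cc2ccc(OCCCCCn3cc(CNC(=O)CCCCC4CCSS4)nn3)cc2oc1=O` gives 22.2%, which is the lowest of the three numbers; the gap to compound 1 and the larger gap to compound 2 both lie beyond the usual scatter, so compound 3 stands clearly weaker than its two companions in this assay.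

The next compound, compound 4 `O=C(CCCCC1CCSS1)NCc1cn(CCCCCOc2ccc3cc(-c4ccc(Cl)c(Cl)c4)c(=O)oc3c2)nn1`, has not been measured yet. It differs from compound 3 in one place: 3,4-dichlorophenyl in place of acetyl on an aromatic carbon. The rest of the molecule, including the long chain and the ring-containing tail, is kept unchanged.

Within the data shown here, no step between two measured compounds isolates this kind of exchange, so the expectation rests on the spread of the three numbers. Compound 4 is expected to move upward, from compound 3 by a number 25.8 percentage points higher from compound 3 to compound 4 (beyond the scatter), because compound 1 gives 52.8%. The estimated value for compound 4 in this assay is 48%, most likely between 28% and 68%.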

Compound 4, a percentage reported as activity, at one concentration (the size of the read-out at that concentration, not a potency): 54.8%
Compound 4: middle estimate off by 6.8 percentage points, on the low side; the measured number falls inside the stated range.
By their numbers in this assay, from the lowest: compound 3; then compounds 1, 4 and 2 (each within the scatter of the next).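

In this assay, among these compounds, putting 3,4-dichlorophenyl in place of acetyl gives a number 32.6 percentage points higher from compound 3 to compound 4 (beyond the scatter), and this is the first step that can be read at a single place on the molecule. It shows that this aromatic carbon, two atoms from the ring oxygen, is not a silent spot: with the long chain and the tail kept unchanged, the group placed there alters the read-out substantially. Nothing measured here says what lies behind this step.

As far as these compounds go, it remains open whether the higher number needs the aromatic ring, the two chlorines or both, which an unsubstituted phenyl group could help to separate. From the compounds shown here alone, it is also open how an amine or a carboxylic acid would behave on this carbon, and whether a shorter chain would change the size of the step.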